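Dropping a Trifluoromethyl Group: Effect on Vero Cell Toxicity

The compounds below may be only part of what the source reports. "The series", "measured", "known", "first", "only" and "open" are said of these compounds alone.

Three compounds have been measured in an ADME assay on Vero cells (Chlorocebus sabaeus) for cytotoxicity, read by crystal violet staining; on this read-out higher numbers stand for lower toxicity in this test and lower numbers for higher toxicity in this test:

Compound 1, `O=[N+]([O-])c1cccc(/N=N/Nc2cccc([N+](=O)[O-])c2)c1`: > 100000 nM.
Compound 2, `Cc1c(/N=N/c2ccccc2)ccc(NC[C@@H]2CCCN3CCCC[C@H]23)c1C`: 60000 nM.
Compound 3, `FC(F)(F)c1cccc(/N=N/c2ccc(NC[C@@H]3CCCN4CCCC[C@H]34)c3c2CCCC3)c1`: 50000 nM.

For compound 1 the result is only a limit of the test, > 100000 nM, and not a number; this is the limit described as the limit of > 100000 nM in this assay, at which 1 of the 3 values shown sits. Among the two real numbers, compound 3 has the lowest, but compound 2 lies within the usual scatter of it, so no order between the two can be read from these data.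

Compound 4, `c1ccc(/N=N/c2ccc(NC[C@@H]3CCCN4CCCC[C@H]34)c3c2CCCC3)cc1`, has not yet been measured in this assay. It differs from compound 3 in one place: hydrogen in place of trifluoromethyl on an aromatic carbon. The change leaves the core and the rest of the molecule untouched; only a trifluoromethyl group on an aromatic carbon of a six-membered aromatic ring of carbon only is replaced by hydrogen.

Among the measured compounds shown here, no measured pair in this set differs in exactly this way, so the size of the step can only be estimated. The step from compound 3 to compound 4 in this assay, a 1.2-fold higher number from compound 3 to compound 4 (0.08 log units; within the scatter), is expected to be none beyond the scatter, since compound 2, which also lacks a trifluoromethyl group, gives 60000 nM, close to compound 3. Compound 4 is therefore expected to give about 60000 nM, with a likely range from 30000 nM to 120000 nM.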

Compound 4, half-maximal cytotoxic concentration: 80000 nM
Compound 4: the middle estimate sits 1.3-fold (0.12 log units) below what was measured; measured number inside the range.
By their numbers in this assay, from the lowest: compounds 3, 2 and 4 (each within the scatter of the next). At a limit, above all of these: compound 1.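

Among the compounds shown here, this pair gives the first direct reading of the change at this position. In this assay, replacing the trifluoromethyl on the aromatic ring with hydrogen, which turns the 3-(trifluoromethyl)phenyl group into phenyl, gives a 1.6-fold higher number from compound 3 to compound 4 (0.20 log units; within the scatter). Four heavy atoms can therefore leave this place, meta to a large group, with no effect that this test can distinguish from ordinary repeat variation, so compound 3 and compound 4 cannot be ranked against each other. Nothing measured here explains why the swap has so little effect.

On these data alone, it remains open whether a different group at the same place, such as an amine, a carboxylic acid or a nitrile, would give a step beyond the scatter. As far as these compounds go, it is also open whether removing a trifluoromethyl group would be as uneventful on a different core, as this single pair speaks only for the core shared by compound 3 and compound 4.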